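Carbamate to thiocarbamate on the shared core

The source may report more compounds than this note shows. Statements on the series, on what has been measured and on what is new or still open speak of the compounds shown alone.

Compound 1 `Cc1nc(S(C)(=O)=O)ccc1Oc1ncnc(OC2CCN(C(=O)O[C@H](C)CF)CC2)c1F`: 79%
Compound 2 `Cc1nc(S(C)(=O)=O)ccc1Oc1ncnc(OC2CCN(C(=O)O[C@@H](C)CF)CC2)c1F`: 84%
Compound 3 `Cc1nc(S(C)(=O)=O)ccc1Oc1ncnc(OC2CCN(C(=O)OC3COC3)CC2)c1F`: 66%

Of the compounds shown here, three with a common core have been measured in a functional assay on isolated protein for inhibition of Glucose-dependent insulinotropic receptor (Rattus norvegicus), read by HTRF and cAMP accumulation; a higher number here means a larger maximal response, a lower number a smaller maximal response. Compound 1 and compound 2 differ only in configuration, and the change a number 5 percentage points higher from compound 1 to compound 2 (within the scatter) lies within the scatter, a point that rests on (the fact that compounds 1 and 2 differ only in the configuration as drawn). Compound 2 holds the highest of the three numbers; compound 1 stands within the scatter of it, while compound 3 sits beyond the scatter below it.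

Compound 4 `Cc1nc(S(C)(=O)=O)ccc1Oc1ncnc(OC2CCN(C(=O)SC(C)C)CC2)c1F` is yet to be measured. It departs from compound 2 by a group of 4 heavy atoms (3 carbon, 1 sulfur; no ring) in place of a group of 5 heavy atoms (3 carbon, 1 oxygen, 1 fluorine; no ring), on a carbonyl carbon.

The measured steps that touch the same place are a number 13 percentage points lower from compound 1 to compound 3 (beyond the scatter) and a number 18 percentage points lower from compound 2 to compound 3 (beyond the scatter), both modest decreases when oxetan-3-yl replaces 1-(fluoromethyl)ethyl on an oxygen next to a carbonyl group. Among the measured compounds shown here, the change to compound 4 is of a different kind, exchanging the oxygen-linked group for isopropylsulfanyl on the carbonyl carbon, so no measured step matches it directly. A modest step in this assay, at most like those seen, seems the most reasonable expectation, with a fall slightly more likely than a rise.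

Compound 4 is therefore expected to give 75%, within 60% to 90%, an estimated step of a number 9 percentage points lower from compound 2 to compound 4 (within the scatter).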

Compound 4, largest response reached (reported as efficacy), in percent of the reference or control that the assay uses: 81%
Compound 4: the middle estimate sits 6 percentage points below what was measured; the range from low to high includes it.
By their numbers in this assay, from the lowest: compound 3; then compounds 1, 4 and 2 (each within the scatter of the next).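

In this assay, isopropylsulfanyl on the carbonyl carbon keeps the response within the scatter of both fluorinated carbamates, with a number 3 percentage points lower from compound 2 to compound 4 (within the scatter) and a number 2 percentage points higher from compound 1 to compound 4 (within the scatter), so this place accepts a sulfur link and a group with no defined stereocentre. Against the oxetan-3-yl carbamate the picture differs, with a number 15 percentage points higher from compound 3 to compound 4 (beyond the scatter), which leaves compound 3 as the only one of the four beyond the scatter of all the others. Nothing shown here gives a cause for these steps.

The compounds shown do not separate the effect of the sulfur from that of the isopropyl chain, for which an isopropyl group on the oxygen would be the direct comparison. From the compounds shown here alone, how a longer chain on the sulfur, or an amine on the carbonyl carbon, would read in this assay also stays open.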